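A few compounds are considered here, and "the series" means these few. Any claim that something is new, unique, unknown or untested is made for them only; others in the source may bear on it.

Within the data shown here, compound 2 `CCCC[C@H](NC(=O)[C@H](CCCCN)NC(=O)[C@H](CCCNC(=N)N)NC(=O)c1ccc(/C=C2\SC(=O)N(CCCC)C2=O)cc1)C(N)=O` gives 1.18 10^-6 cm/s in an ADME assay for permeability, using PAMPA (a higher number here means that the compound crosses the layer faster, a lower number that the compound crosses the layer more slowly), one of only two values measured so far; compound 1 `CCCC[C@H](NC(=O)[C@H](CCCCN)NC(=O)[C@H](CCCNC(=N)N)NC(=O)c1ccc(/C=C2\SC(=O)N(C3CCCCC3)C2=O)cc1)C(N)=O` gives 1.69 10^-6 cm/s, and the single measured step, a 1.4-fold lower number from compound 1 to compound 2 (0.16 log units; within the scatter), stays within the scatter. Compound 3 `CCCC[C@H](NC(=O)[C@H](CCCCN)NC(=O)[C@H](CCCNC(=N)N)NC(=O)c1ccc(/C=C2\SC(=O)N(Cc3ccc(Cl)cc3)C2=O)cc1)C(N)=O` differs from compound 2 by 4-chlorophenyl in place of propyl on a saturated chain carbon bound to an amide-type nitrogen in a ring. This change touches the same chain as the earlier step, and because a 1.4-fold lower number from compound 1 to compound 2 (0.16 log units; within the scatter) stayed within the scatter, no move beyond the scatter is expected here either. Compound 3 is therefore expected to show a 1.1-fold higher number from compound 2 to compound 3 (0.04 log units; within the scatter). The estimate for compound 3 is 1.3 10^-6 cm/s, with a range from 0.6 10^-6 cm/s to 2.8 10^-6 cm/s.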

Compound 3, apparent permeability: 1.11 10^-6 cm/s
Estimate against measurement, compound 3: 1.2-fold (0.07 log units) above; low and high end bracket the measured number.
By their numbers in this assay, from the lowest: compounds 3, 2 and 1 (each within the scatter of the next).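

At this place, on an amide-type nitrogen in a ring, 4-chlorobenzyl brings in an aromatic ring with chlorine, yet this assay stays within the scatter for both new steps (a 1.1-fold lower number from compound 2 to compound 3 (0.03 log units; within the scatter)) and (a 1.5-fold lower number from compound 1 to compound 3 (0.18 log units; within the scatter)). Butyl, cyclohexyl and 4-chlorobenzyl therefore cannot be told apart here, despite their different shapes and sizes. No measured evidence explains this result.

Still open, on these data alone, is whether an amine or a carboxylic acid at this place would move the number beyond the scatter. As far as these compounds go, a much longer chain is an equally open case.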